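From furan to nitrophenyl in an adenosine receptor series

A few compounds are considered here, and "the series" means these few. Any claim that something is new, unique, unknown or untested is made for them only; others in the source may bear on it.

Of the compounds shown here, three sharing one core have been measured in an assay (strain Wistar) for displacement of a labelled ligand from adenosine receptor A1 (Rattus norvegicus), read by scintillation counting; a lower number here means a stronger inhibitor, a higher number a weaker inhibitor. Compound 1 `COc1ccc(Cl)cc1C(=O)Nc1nc(-c2ccccc2)nc2c1nnn2Cc1ccccc1` gives 7150 nM. Compound 2 `COc1ccccc1C(=O)Nc1nc(-c2ccccc2)nc2c1nnn2Cc1ccccc1` gives 1520 nM, and a 4.7-fold lower number from compound 1 to compound 2 (0.67 log units; beyond the scatter). Compound 3 `O=C(Nc1nc(-c2ccccc2)nc2c1nnn2Cc1ccccc1)c1ccoc1` gives 10 nM, the lowest of the three numbers; its nearest neighbour is compound 2, and the steps of a 150-fold lower number from compound 2 to compound 3 (2.18 log units; beyond the scatter) and a 720-fold lower number from compound 1 to compound 3 (2.85 log units; beyond the scatter) both point the same way.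

Compound 4 `O=C(Nc1nc(-c2ccccc2)nc2c1nnn2Cc1ccccc1)c1ccc([N+](=O)[O-])cc1` differs from compound 3 in one place: 4-nitrophenyl in place of furan-3-yl on a carbonyl carbon. Within the data shown here, two measured steps bear on this change, since both replace a substituted phenyl carbonyl with the furan carbonyl and both lower the number strongly: a 720-fold lower number from compound 1 to compound 3 (2.85 log units; beyond the scatter) and a 150-fold lower number from compound 2 to compound 3 (2.18 log units; beyond the scatter). Compound 4 moves the other way, back from furan to a six-membered carbon ring, though with a different substituent than either measured phenyl. A step upward in this assay beyond the scatter is therefore expected for compound 4, of roughly a 20-fold higher number from compound 3 to compound 4 (1.30 log units; beyond the scatter). The estimate for compound 4 in this assay is 200 nM, within 30 nM to 2000 nM.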

Compound 4, inhibition constant: 24 nM
The estimate for compound 4 lay 8.3-fold (0.92 log units) above the measured number; measured number below the stated range.
By their numbers in this assay, from the lowest: compound 3; then compound 4; then compound 2; then compound 1.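

A six-membered carbon ring on this carbonyl carbon need not cost much strength: 4-nitrophenyl in place of furan-3-yl gives just a 2.4-fold higher number from compound 3 to compound 4 (0.38 log units; beyond the scatter) even though that modest step is beyond the usual scatter. The same group gives a 63-fold lower number from compound 2 to compound 4 (1.80 log units; beyond the scatter) against 2-methoxyphenyl and a 300-fold lower number from compound 1 to compound 4 (2.47 log units; beyond the scatter) against 5-chloro-2-methoxyphenyl, so among these compounds the large gaps follow the groups carried on the phenyl ring, not the presence of the ring alone. Nothing available here explains these differences.

Still open, as far as these compounds go, is whether the nitro group itself matters, or only its place on the ring. A plain phenyl, a 4-aminophenyl or a 4-methoxyphenyl group on the same carbonyl carbon would help separate the ring from its substituent.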